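The source may hold more compounds than are shown below. What is called first, only, known or untested is meant among the compounds shown, and "the series" means these compounds.

Compounds measured:
Compound 1 `CO/N=C1\C[C@@H](c2ccccc2)N[C@@H](c2ccccc2)[C@@H]1C` gives 113000 nM in a functional assay on HeLa cells (Homo sapiens) for inhibition, read by MTT assay, with a stated time of 24 h; a higher number here means a weaker inhibitor, a lower number a stronger inhibitor.
Compound 2 `CC[C@@H]1/C(=N/OC)C[C@@H](c2ccccc2)N[C@H]1c1ccccc1` gives 57300 nM in this assay.

Among the measured compounds shown here, compound 2 stands with the lowest of the two numbers measured so far, with compound 1 nearest to it, and the only step between the two, a 2.0-fold lower number from compound 1 to compound 2 (0.29 log units; within the scatter), lies within the scatter. The two compounds therefore cannot be told apart on these numbers.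

Compound 3 `CO/N=C1\C[C@@H](c2ccccc2)N[C@@H](c2ccccc2)[C@@H]1C(C)C` differs from compound 2 by methyl in place of hydrogen on a saturated chain carbon bound to a saturated chain carbon and a saturated ring carbon. For the measured compounds named here, the one measured step that bears on this change is the earlier addition of a methyl on the same saturated chain carbon, a 2.0-fold lower number from compound 1 to compound 2 (0.29 log units; within the scatter), which was within the scatter. Nothing in the data shows that a second methyl on that chain carbon should move the number beyond the scatter either. A step of about a 1.4-fold lower number from compound 2 to compound 3 (0.13 log units; within the scatter) in this assay is therefore expected from compound 2 to compound 3, which is no change beyond the scatter. Compound 3 is accordingly estimated at 42000 nM in this assay, with a range from 14000 nM to 130000 nM.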

Compound 3, half-maximal inhibitory concentration: 49500 nM
The estimate for compound 3 lay 1.2-fold (0.07 log units) below the measured number; low and high end bracket the measured number.
By their numbers in this assay, from the lowest: compounds 3, 2 and 1 (each within the scatter of the next, the first and the last beyond it).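

In this assay, the change from ethyl to isopropyl, with methyl in place of hydrogen on a saturated chain carbon bound to a saturated chain carbon and a saturated ring carbon, gives a 1.2-fold lower number from compound 2 to compound 3 (0.06 log units; within the scatter), so this second methyl, like the first, does not separate the two compounds it links. Read as one change on a saturated ring carbon, isopropyl in place of methyl gives a 2.3-fold lower number from compound 1 to compound 3 (0.36 log units; beyond the scatter), which makes it the first step in this set to pass the scatter, though only modestly. Compound 2 stays within the scatter of both compound 1 and compound 3, so the two single methyl additions cannot be told apart from the scatter, and only the two ends of the series, methyl and isopropyl, stand apart.

At this position the compounds shown carry only methyl, ethyl and isopropyl, so it remains open whether a longer chain such as n-butyl, a phenyl ring, a hydroxyl or an amine there would move the number further. All of these numbers also remain high and come from a single cell assay, and no measurement at hand explains the steps seen here.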